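The source may hold more compounds than are shown below. What is called first, only, known or untested is meant among the compounds shown, and "the series" means these compounds.

Measured compounds:
- compound 1, `Cc1n[nH]c2ccc(-c3nc4cnc(N5CCN(C)CC5)cn4c3Nc3cccc(F)c3)cc12`: 18.5%
- compound 2, `Cc1n[nH]c2ccc(-c3nc4cnc(N5CCN(C)CC5)cn4c3Nc3ccccc3Cl)cc12`: 58.1%
- compound 3, `Cc1n[nH]c2ccc(-c3nc4cnc(N5CCN(C)CC5)cn4c3Nc3cccc(Cl)c3)cc12`: 0%

In a functional assay on MV4-11 cells (Homo sapiens) for inhibition, with a stated time of 120 h, tested at 10 uM (a lower number here means less inhibition, a higher number more inhibition at the concentration tested (going by the name of the read-out)), compound 1 gives 18.5% and stands second highest of the three numbers. Its nearest neighbour is compound 3, which gives 0%; the step of a number 18.5 percentage points lower from compound 1 to compound 3 (beyond the scatter) is beyond the scatter. Furthest away is compound 2, which gives 58.1%; the step of a number 39.6 percentage points higher from compound 1 to compound 2 (beyond the scatter) is large, as is the step of a number 58.1 percentage points lower from compound 2 to compound 3 (beyond the scatter) in the other direction.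

Compound 4, `Cc1n[nH]c2ccc(-c3nc4cnc(N5CCN(C)CC5)cn4c3Nc3ccc(Br)cc3)cc12`, is the unmeasured member of the set. Its difference from compound 1 is 4-bromophenyl in place of 3-fluorophenyl on a nitrogen on an aromatic ring. Among the measured compounds shown here, none of the measured steps changes the same ring in the same way: the step of a number 18.5 percentage points lower from compound 1 to compound 3 (beyond the scatter) swaps one halogen for another at the same place on the phenyl ring, while a number 39.6 percentage points higher from compound 1 to compound 2 (beyond the scatter) and a number 58.1 percentage points lower from compound 2 to compound 3 (beyond the scatter) move a chloro group between places. What these three show is that both the halogen and where it sits shift the read-out beyond the scatter, and in either direction, so the bromo group at a new place on the ring gives no firm basis for a direction. Compound 4 is therefore expected to land near compound 1, with a step of a number 1.5 percentage points higher from compound 1 to compound 4 (within the scatter) that need not exceed the scatter, and a wide range. The estimate for compound 4 is 20%, between 0% and 50%.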

Compound 4, a percentage reported as inhibition, at one concentration (the size of the read-out at that concentration, not a potency): 83%
Beside the measured number, compound 4's estimate is 63 percentage points below it; the whole stated range lies below it.
By their numbers in this assay, from the lowest: compound 3; then compound 1; then compound 2; then compound 4.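

In this assay, the aromatic ring on this nitrogen turns out to allow far more inhibition than the earlier halogen changes showed: 4-bromophenyl in place of 3-fluorophenyl gives a number 64.5 percentage points higher from compound 1 to compound 4 (beyond the scatter), and 4-bromophenyl in place of 3-chlorophenyl gives a number 83 percentage points higher from compound 3 to compound 4 (beyond the scatter). The 2-chlorophenyl group had given the highest number until now, yet 4-bromophenyl in its place gives a number 24.9 percentage points higher from compound 2 to compound 4 (beyond the scatter), which puts compound 4 at the top of the four, with each of its steps beyond the scatter. The groups that leave and enter have the same counts of heavy atoms and hydrogen-bond donors and acceptors, so these large differences arise with only the halogen and its place on the ring changing.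

The compounds shown change the halogen and its place together in every step to compound 4, so it stays open which of the two carries the rise, a question that a 4-chlorophenyl or a 3-bromophenyl group on the same nitrogen would address. Nothing given here accounts for the rise in inhibition at this position.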